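The compounds below may be only part of what the source reports. "The series", "measured", "known", "first", "only" and "open" are said of these compounds alone.

Measured so far:
compound 1, `O=C1[C@@H](NS(=O)(=O)c2ccc(-c3ccncc3)s2)CCN1Cc1cc2[nH]cccc-2n1`: 35%
compound 2, `O=C1[C@@H](NS(=O)(=O)c2ccc(-c3ccncc3)s2)CCN1CCNc1ccncc1`: 41%

In an assay on isolated protein for inhibition of coagulation factor X (Oryctolagus cuniculus), tested at 1 uM (on this read-out higher numbers stand for more inhibition at the one concentration tested (going by the name of the read-out) and lower numbers for less inhibition), compound 1 gives 35% and compound 2 gives 41%. On these two numbers compound 2 carries the larger reading, but the step of a number 6 percentage points higher from compound 1 to compound 2 (within the scatter) lies within the scatter, so nothing separates the two compounds on this read-out.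

Compound 3, `O=C1[C@@H](NS(=O)(=O)c2ccc(-c3ccncc3)s2)CCN1Cc1cc2cc[nH]cc-2n1`, is not yet measured. It differs from compound 2 in one place: a group of 9 heavy atoms (7 carbon, 2 nitrogen; one five-membered aromatic ring with 1 hetero atom, one six-membered aromatic ring with 1 hetero atom) in place of a group of 8 heavy atoms (6 carbon, 2 nitrogen; one six-membered aromatic ring with 1 hetero atom), on a saturated chain carbon bound to an amide-type nitrogen in a ring. Within the data shown here, the only measured step that bears on a change of this kind is a number 6 percentage points higher from compound 1 to compound 2 (within the scatter), which at the same place replaced a group of one five-membered aromatic ring with 1 hetero atom and one six-membered aromatic ring with 1 hetero atom by the group that now leaves, without a shift beyond the scatter. The step in the opposite sense is therefore expected to be small too: a number 4 percentage points lower from compound 2 to compound 3 (within the scatter) is the estimate, with no direction beyond the scatter. Compound 3 is expected to give about 37%, estimated to lie between 17% and 57%.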

Compound 3, a percentage reported as inhibition, at one concentration (the size of the read-out at that concentration, not a potency): 50%
Estimate against measurement, compound 3: 13 percentage points below, and the stated range covers the measured number.
By their numbers in this assay, from the lowest: compounds 1, 2 and 3 (each within the scatter of the next, the first and the last beyond it).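

In this assay, among these compounds, there is now a number 15 percentage points higher from compound 1 to compound 3 (beyond the scatter) and this is the first step beyond the scatter. It joins two groups with the same heavy-atom count and the same pair of aromatic rings, so the place on the saturated chain carbon bound to the amide-type nitrogen responds to how those atoms are arranged within the group, not only to their count. Against the ((pyridin-4-yl)amino)methyl group the picture is different: a number 9 percentage points higher from compound 2 to compound 3 (within the scatter) leaves these two groups unseparated, and nothing available explains either step.

Still open, on these data alone, is how a plain phenyl ring, a primary amine or a carboxylic acid at this place would read on the shared core. Also open, as far as these compounds go, is whether the difference between compound 1 and compound 3 holds at other concentrations, since each reading here comes from a single concentration and is not a potency.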